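Thiophene Amide on a Phenyl Chalcone: Expected Cytotoxicity

The source may report more compounds than this note shows. Statements on the series, on what has been measured and on what is new or still open speak of the compounds shown alone.

The measured compounds:
compound 1 `Nc1ccc(C(=O)/C=C/c2ccco2)cc1` gives 21000 nM in a functional assay on HCT-116 cells (Homo sapiens) for cytotoxicity, read by resazurin assay, with a stated time of 48 h; a higher number here means that more compound is needed for the effect, a lower number that less compound is needed
compound 2 `O=C(/C=C/c1ccco1)c1ccc(NC(=O)c2cccs2)cc1` gives 33000 nM in this assay
compound 3 `Nc1ccc(C(=O)/C=C/c2ccccc2)cc1` gives 27000 nM in this assay

Compound 3 sits in the middle of these three numbers, yet all three lie within the scatter of one another: its gap to compound 2 and its gap to compound 1 are both inside the usual spread of repeated measurements, so no ranking among them can be claimed.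

The unmeasured compound 4 `O=C(/C=C/c1ccccc1)c1ccc(NC(=O)c2cccs2)cc1` differs from compound 3 in one place:
(thiophen-2-yl)carbonyl in place of hydrogen on a nitrogen on an aromatic ring

Going by the values given here, one measured step bears on this change. Compound 1 and compound 2 show the same replacement on the furan-bearing core, and there a 1.6-fold higher number from compound 1 to compound 2 (0.20 log units; within the scatter) stayed within the scatter. Among the compounds with values here, that step is the only guide available, and the core of compound 3 differs from the core of compound 1 only in the ring at the far end of the double bond, so the expectation is a step of similar size, that is, nothing beyond the scatter.

For compound 4 the estimate in this assay is therefore 35000 nM, with a range from 17000 nM to 75000 nM. The step this estimate means, a 1.3-fold higher number from compound 3 to compound 4 (0.11 log units; within the scatter), is expected to stay within the scatter.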

Compound 4, half-maximal effective concentration: 12000 nM
For compound 4 the middle estimate is 2.9-fold (0.46 log units) above the measured one; the measured number lies below the stated range.
By their numbers in this assay, from the lowest: compounds 4, 1, 3 and 2 (each within the scatter of the next, the first and the last beyond it).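

On the core of compound 3, (thiophen-2-yl)carbonyl in place of hydrogen on a nitrogen on an aromatic ring gives a step that the furan-bearing pair did not show in this assay: a 2.3-fold lower number from compound 3 to compound 4 (0.35 log units; beyond the scatter). With this amide in place, phenyl in place of furan-2-yl on a double-bonded chain carbon also gives a step beyond the scatter, a 2.8-fold lower number from compound 2 to compound 4 (0.44 log units; beyond the scatter), whereas compound 1 and compound 3, which carry the free amino group, lie within the scatter of each other. The result of this replacement therefore does not carry over from one core to the other: the same change on two cores in this assay, a 1.6-fold higher number (0.20 log units; within the scatter) from compound 1 to compound 2 and a 2.3-fold lower number (0.35 log units; beyond the scatter) from compound 3 to compound 4, 3.5-fold (0.55 log units) apart, beyond the scatter of two such steps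

The compounds shown leave open whether the lower number on the phenyl-bearing core belongs to the thiophene ring or to the amide as such, which an acetyl or a benzoyl group on the same nitrogen would help to separate. They also leave open whether the difference between the two cores extends to other groups on the double-bonded chain carbon, such as thiophen-2-yl or pyridinyl.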